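The compounds below may be only part of what the source reports. "The series", "measured", "known", "first", "only" and "open" are said of these compounds alone.

Compound 1 `CN(C)CCC(OC(=O)c1ccc(C(F)(F)F)cc1)c1ccc(Cl)cc1`: 1740 nM
Compound 2 `Cc1ccccc1C(=O)NC(CCN(C)C)c1ccc(Cl)cc1`: 3550 nM

Both were tested in an assay on NIH3T3 cells with Urotensin-2 receptor (Homo sapiens) as the target; a higher number here means that more compound is needed for the effect, a lower number that less compound is needed. Of these two numbers, compound 2 gives the higher one, 3550 nM, while compound 1 gives a lower one, 1740 nM, a gap beyond the usual scatter. Compound 3 `Cc1ccc(C)c(C(=O)NC(CCN(C)C)c2ccc(Cl)cc2)c1` has not yet been measured. It differs from compound 2 in one place: methyl in place of hydrogen on an aromatic carbon. Within the data shown here, no measured pair shows a change of this kind, so nothing supports expecting a large shift. The expected step is small, a 1.2-fold lower number from compound 2 to compound 3 (0.07 log units; within the scatter), and may not exceed the scatter. Compound 3 is estimated at about 3000 nM, between 1200 nM and 8000 nM.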

Compound 3, half-maximal effective concentration: 2880 nM
For compound 3 the middle estimate is 1.0-fold (0.02 log units) above the measured one; the measured number falls inside the stated range.
By their numbers in this assay, from the lowest: compounds 1, 3 and 2 (each within the scatter of the next, the first and the last beyond it).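

Going from the 2-methylphenyl to the 2,5-dimethylphenyl group gives a 1.2-fold lower number from compound 2 to compound 3 (0.09 log units; within the scatter) in this assay. This place on the ring, meta to a large group and para to a methyl group, therefore takes an added methyl with no change that stands out from the scatter. No measurement at hand explains this result. Going by these compounds, whether a chlorine atom, a methoxy group or an ethyl group at this place would shift the number stays open, as does the effect of a methyl elsewhere on this ring.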